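The source may hold more compounds than are shown below. What is called first, only, known or untested is meant among the compounds shown, and "the series" means these compounds.

Compound 1 `Cc1ccc(Cl)cc1-n1nncc1CN1C(=O)C2(C(C#N)=C(N)Oc3c2c2nc4ccccc4nc2c2ccccc32)c2ccccc21`: in an ADME assay on L02 cells (Homo sapiens) for antiproliferative activity, read by MTT assay, with a stated time of 48 h (on this read-out lower numbers stand for stronger inhibition and higher numbers for weaker inhibition), compound 1 gives > 50000 nM, which is a limit of the assay rather than a number.
Compound 2 `N#CC1=C(N)Oc2c(c3nc4ccccc4nc3c3ccccc23)C12C(=O)N(Cc1cnnn1-c1ccc(F)c(Cl)c1)c1ccccc12`: in this assay compound 2 gives > 50000 nM, also a limit.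
Compound 3 `CCOc1ccccc1-n1nncc1CN1C(=O)C2(C(C#N)=C(N)Oc3c(N)cc4nc5ccccc5nc4c32)c2ccccc21`: in this assay compound 3 gives > 50000 nM, again a limit.

Compound 3 therefore stands at a limit, as do both other measured compounds, all three resting at the limit of > 50000 nM in this assay, at which 3 of the 3 values shown sit. Compound 4 `N#CC1=C(N)Oc2c(N)cc3nc4ccccc4nc3c2C12C(=O)N(Cc1cnnn1-c1ccc(Cl)cc1[N+](=O)[O-])c1ccccc12` differs from compound 3 by 4-chloro-2-nitrophenyl in place of 2-ethoxyphenyl on an aromatic nitrogen. For the measured compounds named here, the single measured step, a step that the two limits leave unreadable from compound 1 to compound 2, also swaps the group on the aromatic nitrogen, but it runs between two limits and its size cannot be read. Going by the values given here, no measured step gives a direction, so compound 4 is expected to stay at the limit as well, the expected step being a number no higher from compound 3 to compound 4 (the limit leaves the size open). The estimate for compound 4 in this assay is 50000 nM, ranging from 20000 nM to 100000 nM.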

Compound 4, half-maximal inhibitory concentration: > 50000 nM
Compound 4 was reported as a limit; the forecaster's own chance of this, stated with the estimate: 85%; the middle value sits exactly at the limit.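

Compound 3 and compound 4 both rest at a limit, so the step between them cannot be read: the limit of > 50000 nM in this assay, at which 4 of the 4 values shown sit. The compounds shown leave open how far each one lies beyond that limit in this assay, and whether changing the group on the aromatic nitrogen alters the read-out at all.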